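This account rests on a few compounds, and the source may have more. Where it says the series, first, only, none or still open, it means among the compounds named here.

Of the compounds shown here, three built on a shared core have been tested in a functional assay on MCF7 cells (Homo sapiens) for antiproliferative activity, read by MTT assay, with a stated time of 48 h, tested at 25 uM; a higher number here means a weaker effect of the compound at the concentration tested, a lower number a stronger effect. Compound 1 `OCC(O)Cn1nc2c(Br)c(Br)c(Br)c(Br)c2n1` gives 111% in this assay. Compound 2 `OC(CCn1nc2c(Br)c(Br)c(Br)c(Br)c2n1)c1ccc(Br)cc1` gives 105%, and compound 3 `OC(CCn1nc2c(Br)c(Br)c(Br)c(Br)c2n1)c1ccccc1` gives 105%. Compound 3 stands level with compound 2 at the digits shown, the two together being the lowest of the three numbers, and the value of compound 1 differs from that of compound 3 only within the scatter. Going by the values given here, the single step that can be measured, no change at the digits printed from compound 2 to compound 3 (within the scatter), exchanges bromo for hydrogen on an aromatic carbon and leaves the read-out unmoved beyond the scatter.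

Compound 4 `CC(O)CCn1nc2c(Br)c(Br)c(Br)c(Br)c2n1` has not yet been measured. It differs from compound 3 in one place: methyl in place of phenyl on a saturated chain carbon bound to an oxygen on a saturated carbon and a saturated chain carbon. Among the compounds with values here, no measured step exchanges a phenyl for a methyl, so the only guide is the whole set: every change among compounds 1, 2 and 3 kept the read-out within the scatter, including compound 1, which carries no phenyl at all and gives 111%. The step of a number 2 percentage points higher from compound 3 to compound 4 (within the scatter) is therefore expected to be small, with no clear direction. Compound 4 is estimated at 107%, in a range from 95% to 120%.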

Compound 4, a percentage reported as activity, at one concentration (the size of the read-out at that concentration, not a potency): 73%
Beside the measured number, compound 4's estimate is 34 percentage points above it; the whole stated range lies above it.
By their numbers in this assay, from the lowest: compound 4; then compounds 2, 3 and 1 (each within the scatter of the next).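

In this assay, going by these compounds alone, the group on the saturated chain carbon bound to an oxygen turns out to matter: methyl in place of phenyl gives a number 32 percentage points lower from compound 3 to compound 4 (beyond the scatter) and is the first change in this set to pass beyond the scatter. Methyl in place of 4-bromophenyl at the same carbon gives a number 32 percentage points lower from compound 2 to compound 4 (beyond the scatter) and tells the same story, so among these compounds, either aromatic ring goes with a high number and methyl with a clearly lower one, which here means a stronger effect. Losing the ring is not enough on its own, however, and compound 1 goes against any such simple rule: it also has no phenyl, yet 2-hydroxypropyl in place of 1,2-dihydroxyethyl on a saturated chain carbon bound to an aromatic nitrogen gives a number 38 percentage points lower from compound 1 to compound 4 (beyond the scatter) and shows that the rest of the chain counts too.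

On these data alone, it remains open whether ethyl, a longer chain or an amine at the carbon that now carries methyl would lower the number further, keep it or raise it again. The data at hand offer no measurement that explains why methyl behaves so differently from phenyl.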